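The source may report more compounds than this note shows. Statements on the series, on what has been measured and on what is new or still open speak of the compounds shown alone.

Measured so far:

Compound 1 `COc1c(Br)cc(Br)cc1C(=O)Nc1ccccc1` — in an ADME assay on HEK293 cells (Homo sapiens) for cytotoxicity, read by reporter gene assay and resazurin assay, with a stated time of 48 h (a higher number here means that more compound is tolerated, a lower number that less compound is tolerated), compound 1 gives > 100000 nM, which is a limit of the assay and not a number.
Compound 2 `O=C(Nc1ccccc1)c1cc(Br)cc(Br)c1` — in this assay compound 2 gives > 100000 nM, again a limit.
Compound 3 `COc1ccccc1C(=O)Nc1ccc(Sc2nc3ccccc3s2)cc1` — in this assay compound 3 gives > 100000 nM, also a limit.

Within the data shown here, all three values sit at the same point, (the limit of > 100000 nM in this assay, at which 3 of the 3 values shown sit), so no compound can be set apart from another on these data.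

The change from compound 1 to compound 2 is hydrogen in place of methoxy on an aromatic carbon. Its step in this assay is a step that the two limits leave unreadable from compound 1 to compound 2; both ends are limits, so the size of this step is not readable.

The core of compound 3 differs from the core of compound 1; that difference is not broken down here. Compound 4 `O=C(Nc1ccc(Sc2nc3ccccc3s2)cc1)c1ccccc1` is not yet measured. It differs from compound 3 by hydrogen in place of methoxy on an aromatic carbon. This is the same kind of change as from compound 1 to compound 2, but the surroundings differ: in compound 1 the place is ortho to a bromo group, ortho to a group of 9 heavy atoms and para to a bromo group, while in compound 3 it is ortho to a large group.

Expectation for compound 4 in this assay: the step is estimated at a step that the limit leaves unreadable from compound 3 to compound 4, essentially flat, resting on the fact that compound 3 gives > 100000 nM and that the same kind of change from compound 1 to compound 2 left both values at the limit. Compound 4 is therefore expected at about 150000 nM, within 70000 nM to 400000 nM, most likely reported as a limit.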

Compound 4, half-maximal cytotoxic concentration: > 100000 nM
Compound 4: no number, only a limit; the forecaster's own chance of this, stated with the estimate: 85%; the middle value does not contradict the limit.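

The step between compound 3 and compound 4 cannot be read, since both values are limits of this assay and not numbers, and the same holds for every value in the series: the limit of > 100000 nM in this assay, at which 4 of the 4 values shown sit.

The compounds shown leave open how far any of the four lies from this limit, and whether the change from 2-methoxyphenyl to phenyl has any size in this assay.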